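Extending the sulfonyl substituent toward a linked bithiophene

The source may hold more compounds than are shown below. What is called first, only, known or untested is meant among the compounds shown, and "the series" means these compounds.

Measured so far:
Compound 1 `CCN(C/C=C/C#CC(C)(C)C)Cc1cccc(OCCNS(=O)(=O)c2cccs2)c1` gives 450 nM in a functional assay on HepG2 cells for inhibition of squalene monooxygenase (Homo sapiens); a higher number here means a weaker inhibitor, a lower number a stronger inhibitor.
Compound 2 `CCN(C/C=C/C#CC(C)(C)C)Cc1cccc(OCCN(C)S(=O)(=O)c2ccc(F)cc2)c1` gives 255 nM in this assay.
Compound 3 `CCN(C/C=C/C#CC(C)(C)C)Cc1cccc(OCCN(C)S(=O)(=O)Cc2cccs2)c1` gives 200 nM in this assay.

All three share a core and differ only in the group attached to the sulfonyl sulfur and in the substitution on the sulfonamide nitrogen. Compound 2 stands second highest of the three numbers; its nearest neighbour is compound 3, and the step of a 1.3-fold lower number from compound 2 to compound 3 (0.11 log units; within the scatter) lies within the scatter, while its gap to compound 1 also lies within the scatter. Among the measured compounds shown here, the only step beyond the scatter is a 2.3-fold lower number from compound 1 to compound 3 (0.35 log units; beyond the scatter), and even that is modest.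

Compound 4 `CCN(C/C=C/C#CC(C)(C)C)Cc1cccc(OCCN(C)S(=O)(=O)c2ccc(-c3ccsc3)s2)c1` has not yet been measured. It differs from compound 2 in one place: 5-(thiophen-3-yl)thiophen-2-yl in place of 4-fluorophenyl on a sulfonyl sulfur. The step from compound 2 to compound 3 is the one that most directly bears on this change, since it also replaced the 4-fluorophenyl on the sulfonyl sulfur, and it produced no step beyond the scatter. For the measured compounds named here, no measured compound carries a second ring in this position, so the data give no guidance on whether adding the thiophen-3-yl will shift the number. The expectation for compound 4 is therefore a step within the scatter, a 1.2-fold lower number from compound 2 to compound 4 (0.06 log units; within the scatter), with wide uncertainty. Compound 4 is estimated at 220 nM, expected to fall between 60 nM and 800 nM.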

Compound 4, half-maximal inhibitory concentration: 210 nM
Beside the measured number, compound 4's estimate is 1.0-fold (0.02 log units) above it; the range from low to high includes it.
By their numbers in this assay, from the lowest: compounds 3, 4, 2 and 1 (each within the scatter of the next, the first and the last beyond it).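

On a sulfonyl sulfur whose other neighbour is the sulfonamide nitrogen, 5-(thiophen-3-yl)thiophen-2-yl, with 2 five-membered aromatic rings, replaces 4-fluorophenyl, with one six-membered aromatic ring, and this assay shows a 1.2-fold lower number from compound 2 to compound 4 (0.08 log units; within the scatter), a step that does not separate the two groups. Among the compounds shown here, replacing (thiophen-2-yl)methyl with the same two-ring group gives a 1.1-fold higher number from compound 3 to compound 4 (0.02 log units; within the scatter), so this position, which carried only one ring in the earlier compounds, can hold a second aromatic ring without a step beyond the scatter in either comparison. No measurement here offers an explanation for this result.

The compounds shown leave open whether an amine or a carboxylic acid on the second thiophene would keep the number in this range, and whether a longer chain between the sulfonyl sulfur and the rings would do the same. They also do not separate the effect of the methyl on the sulfonamide nitrogen from that of the carbon linking the thiophene to the sulfur in the step from compound 1 to compound 3.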